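The source may report more compounds than this note shows. Statements on the series, on what has been measured and on what is new or still open speak of the compounds shown alone.

Three compounds built on one shared core, differing only in the aromatic ring at one end, have been examined in an ADME assay on Vero cells (Chlorocebus sabaeus) for cytotoxicity, read by MTT assay, with a stated time of 72 h; on this read-out lower numbers stand for higher toxicity in this test and higher numbers for lower toxicity in this test. For compound 1 `COC(=O)c1cc(-c2cccc(NC(=O)c3ccc(/C=C/C(=O)c4cccs4)cc3)c2)on1` the outcome in this assay is "not determined" (no result reported). For compound 2 `COC(=O)c1cc(-c2cccc(NC(=O)c3ccc(/C=C/C(=O)c4ccc(OC)cc4)cc3)c2)on1` this assay returns only a limit, > 10 ug/mL. For compound 3 `COC(=O)c1cc(-c2cccc(NC(=O)c3ccc(/C=C/C(=O)c4ccc(Cl)cc4)cc3)c2)on1` this assay likewise returns only a limit, > 50 ug/mL. Going by the values given here, the single one-point change among the measured set, chloro in place of methoxy on an aromatic carbon, gives a step that the two limits leave unreadable from compound 2 to compound 3, since both ends of that step sit at the assay's boundaries, the limit of > 10 ug/mL in this assay, at which 1 of the 3 values shown sits, and (the limit of > 50 ug/mL in this assay, at which 1 of the 3 values shown sits). Compound 3 therefore stands at the less toxic edge of what this assay reports, with no numbered value beside it.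

Compound 4 `COC(=O)c1cc(-c2cccc(NC(=O)c3ccc(/C=C/C(=O)c4cccc([N+](=O)[O-])c4)cc3)c2)on1` is the next member of this series. Its difference from compound 3 is 3-nitrophenyl in place of 4-chlorophenyl on a carbonyl carbon. Among the compounds with values here, no measured step touches a nitrophenyl ring, and the one step that is recorded, from methoxy to chloro, is itself unreadable, so nothing in the data points to a direction for this change. Compound 4 is expected to remain in the low-toxicity range, giving an estimated 50 ug/mL in this assay, within 15 ug/mL to 150 ug/mL, which would mean an estimated a number no higher from compound 3 to compound 4 (the limit leaves the size open).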

Compound 4, half-maximal cytotoxic concentration: > 40 ug/mL
Compound 4 ended at the assay's limit; the forecaster's own chance of this, stated with the estimate: 70%; the middle value is on the limit's open side.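

In this assay compound 4 gives only a limit, as do compound 2 and compound 3, so the steps from compound 4 to either of the other two cannot be read. The compounds shown leave open whether exchanging the aromatic ring on the carbonyl carbon changes the half-maximal cytotoxic concentration at all.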